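Swapping the Aryl End of a Shared Chalcone Core

The source may report more compounds than this note shows. Statements on the series, on what has been measured and on what is new or still open speak of the compounds shown alone.

Compound 1 `COc1ccc(/C=C/C(=O)c2ccc(OC)c3c2OC(C)(C)C=C3)c(F)c1` was examined in a functional assay on HCT-116 cells (Homo sapiens) for antiproliferative activity, read by MTT assay, with a stated time of 24 h; a lower number here means a stronger inhibitor, a higher number a weaker inhibitor. In this assay compound 1 gives only a limit, > 10000 nM, not a number. It therefore stands at the limit of > 10000 nM in this assay, at which 2 of the 2 values shown sit. Compound 2 `COc1cc(OC)c(OC)cc1/C=C/C(=O)c1ccc(OC)c2c1OC(C)(C)C=C2` likewise reaches only a limit in this assay, > 10000 nM. Compound 3 `COc1ccc(C(=O)/C=C/c2ccc([N+](=O)[O-])cc2)c2c1C=CC(C)(C)O2` is not yet measured; it differs from compound 1 in one place (4-nitrophenyl in place of 2-fluoro-4-methoxyphenyl on a double-bonded chain carbon bound to a double-bonded chain carbon). Among the compounds with values here, no measured step exists to guide the direction, so the step is expected to be a step that the limit leaves unreadable from compound 1 to compound 3, nothing beyond the scatter. Compound 3 is estimated at 15000 nM, likely between 3000 nM and 60000 nM.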

Compound 3, half-maximal inhibitory concentration: 8880 nM
Compound 3: the middle estimate sits 1.7-fold (0.23 log units) above what was measured, within the range that was stated.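

Unlike compound 1 and compound 2, compound 3 gives a number rather than a limit in this assay, so 4-nitrophenyl at this position brings the series into readable range. Putting it in place of 2-fluoro-4-methoxyphenyl gives an at least 1.1-fold lower number from compound 1 to compound 3 (0.05 log units; that floor lies within the scatter), so no real gain can be claimed from this floor alone. The true size of the step stays unknown because compound 1 has only a limit: the limit of > 10000 nM in this assay, at which 2 of the 3 values shown sit.

On these data alone, how a phenyl ring carrying an amine or a carboxylic acid would behave at this position remains open.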